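Removing a Methoxy Group and Extending the Linker

This account rests on a few compounds, and the source may have more. Where it says the series, first, only, none or still open, it means among the compounds named here.

Measured compounds:
- compound 1 `C=C(Br)C(=O)Nc1cccc(-c2cn3nc(-c4ccc(OC)c(OC)c4)sc3n2)c1`, 42 nM
- compound 2 `C=C(Br)C(=O)Nc1cccc(-c2cn3nc(-c4ccc(OCC)cc4)sc3n2)c1`, 790 nM
- compound 3 `C=C(Br)C(=O)Nc1cccc(-c2cn3nc(Cc4cccc(OC)c4)sc3n2)c1`, 2000 nM

All three were tested in a functional assay on L1210 cells (Mus musculus) for inhibition, read by cell counting, with a stated time of 2 days; on this read-out higher numbers stand for weaker inhibition and lower numbers for stronger inhibition. Compound 3 gives the highest number of the three, which here means the weakest inhibition; the nearest is compound 2, shown by a 2.5-fold higher number from compound 2 to compound 3 (0.40 log units; beyond the scatter), and the furthest is compound 1, shown by a 48-fold higher number from compound 1 to compound 3 (1.68 log units; beyond the scatter).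

Compound 4 `C=C(Br)C(=O)Nc1cccc(-c2cn3nc(CCc4ccccc4)sc3n2)c1` changes compound 3 at this position: benzyl in place of 3-methoxyphenyl on a saturated chain carbon bound to an aromatic carbon. Among the compounds with values here, no measured step removes a methoxy group from a benzyl, so no step bears on this change directly. The steps of a 19-fold higher number from compound 1 to compound 2 (1.27 log units; beyond the scatter) and a 2.5-fold higher number from compound 2 to compound 3 (0.40 log units; beyond the scatter) do show that changes at this position move the number, mostly upward. A modest increase or no change beyond the scatter is therefore expected, as a 1.6-fold higher number from compound 3 to compound 4 (0.20 log units; within the scatter). Compound 4 is estimated at 3200 nM, between 1200 nM and 9000 nM.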

Compound 4, half-maximal inhibitory concentration: 2200 nM
The estimate for compound 4 lay 1.5-fold (0.16 log units) above the measured number; measured number inside the range.
By their numbers in this assay, from the lowest: compound 1; then compound 2; then compounds 3 and 4 (each within the scatter of the next).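

Compound 3 and compound 4 cannot be told apart in this assay (a 1.1-fold higher number from compound 3 to compound 4 (0.04 log units; within the scatter)), so the 3-methoxybenzyl to phenethyl change has no readable effect on this number. Phenethyl still gives weaker inhibition than 4-ethoxyphenyl (a 2.8-fold higher number from compound 2 to compound 4 (0.44 log units; beyond the scatter)) and much weaker inhibition than 3,4-dimethoxyphenyl (a 52-fold higher number from compound 1 to compound 4 (1.72 log units; beyond the scatter)). No measured evidence explains these differences.

On these data alone, whether a chain longer than phenethyl would move the number remains open. So does the effect of an amine or a carboxylic acid at this position.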